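Compound 2 to compound 3: a change on the nitrogen

The source may report more compounds than this note shows. Statements on the series, on what has been measured and on what is new or still open speak of the compounds shown alone.

In a functional assay on Jurkat cells (Homo sapiens) for inhibition, read by CCK-8 assay, with a stated time of 48 h (on this read-out higher numbers stand for weaker inhibition of growth and lower numbers for stronger inhibition of growth), compound 1 (`Cc1ccccc1Nc1nc(NCc2ccccc2)ncc1Cl`) gives > 100000 nM as a limit of the assay. In this assay compound 2 (`Cc1ccccc1Nc1nc(NCc2ccco2)ncc1Cl`) gives > 100000 nM as a limit of the assay. The standing of compound 2 is therefore the limit of > 100000 nM in this assay, at which 2 of the 2 values shown sit, and it has no number of its own.

For the measured compounds named here, the only measured step is a step that the two limits leave unreadable from compound 1 to compound 2 with furan-2-yl in place of phenyl on a saturated chain carbon bound to a nitrogen on an aromatic ring. That step concerns the same side group but gives no size to carry forward.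

Compound 3 (`Cc1ccccc1Nc1nc(Nc2cc(Cl)ccn2)ncc1Cl`) brings a larger change, 4-chloropyridin-2-yl in place of (furan-2-yl)methyl on a nitrogen on an aromatic ring with 4-chloropyridin-2-yl in place of (furan-2-yl)methyl on a nitrogen on an aromatic ring. Going by the values given here, nothing measured so far sets the size of this change, so the expectation is a loose one. Among the compounds with values here, the expected move is an at least 3.3-fold lower number from compound 2 to compound 3 (0.52 log units; beyond the scatter) with stronger inhibition of growth as the only direction a number could show. A report of only a limit in this assay remains about as likely as a number. For compound 3 the estimate is 30000 nM with an expected range from 6000 nM to 100000 nM as its span.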

Compound 3, concentration for 50% growth inhibition: 39600 nM
For compound 3 the middle estimate is 1.3-fold (0.12 log units) below the measured one; the measured number falls inside the stated range.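

For the compounds shown here, this is the first change on this nitrogen to give a number in this assay, and the result moves the series off the limit: an at least 2.5-fold lower number from compound 2 to compound 3 (0.40 log units; beyond the scatter), and likewise an at least 2.5-fold lower number from compound 1 to compound 3 (0.40 log units; beyond the scatter). Both steps are floors, since each starts from a limit of the assay, and the earlier step between compound 1 and compound 2 cannot be read; the nitrogen therefore shows its first readable response here, with 4-chloropyridin-2-yl in place of either group carrying a saturated chain carbon. Compound 3 alone has a number of its own, while the other two compounds remain at the limit: the limit of > 100000 nM in this assay, at which 2 of the 3 values shown sit.

The change removes the chain carbon, exchanges the ring and brings in chlorine all at once, so the compounds shown do not separate these contributions. Going by these compounds, a pyridin-2-yl without the chlorine, a plain phenyl on the same nitrogen, or a 4-methoxypyridin-2-yl would begin to tell which part of the change carries the step, and how far the number can fall remains open.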